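Trimming a tert-butyl group down to methyl

The compounds below may be only part of what the source reports. "The series", "measured", "known", "first", "only" and "open" are said of these compounds alone.

Within the data shown here, in an ADME assay on U2OS cells (Homo sapiens) for cytotoxicity (on this read-out higher numbers stand for lower toxicity in this test and lower numbers for higher toxicity in this test), compound 1 (`CC(C)(O)c1cc2c(-c3ccc(C#N)cc3)nccc2[nH]1`) has no result ("not determined" (no result reported)) and compound 2 (`CC(C)(C)c1ccc(-c2nccc3[nH]c(C(C)(C)O)cc23)cc1`) gives 35300 nM as the only number so far. Compound 3 (`Cc1ccc(-c2nccc3[nH]c(C(C)(C)O)cc23)cc1`) has methyl in place of tert-butyl on an aromatic carbon. Among the measured compounds shown here, no measured pair shows what this swap does in this assay so any forecast stays loose. A change within the usual scatter is expected, leaning slightly toward higher numbers, and a 1.3-fold higher number from compound 2 to compound 3 (0.11 log units; within the scatter) is the estimated step. For compound 3 the estimated value is 45000 nM (range 20000 nM to 100000 nM).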

Compound 3, half-maximal cytotoxic concentration: 38500 nM
For compound 3 the middle estimate is 1.2-fold (0.07 log units) above the measured one, within the range that was stated.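

In this assay, swapping tert-butyl for methyl on this six-membered aromatic ring of carbon only gives a 1.1-fold higher number from compound 2 to compound 3 (0.04 log units; within the scatter), so the read-out does not separate the two groups. A single value for compound 2 could not show that this much smaller group leaves the result within the usual scatter. No supporting measurement explains this outcome.

Compound 1, with a nitrile at this position, has no result, so its steps to compound 2 and compound 3 cannot be read. On these data alone, whether an amine or a carboxylic acid here would shift the number remains open.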